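The source may report more compounds than this note shows. Statements on the series, on what has been measured and on what is new or still open speak of the compounds shown alone.

Three compounds share one core, a tertiary amine nitrogen carrying two saturated chain carbons, and differ only in the group attached to one of those carbons. Compound 1 `N#CCN(Cc1ccccc1)Cc1ccc2ccccc2c1` carries a cyano there and gives 0% in an assay on HEK293 cells for binding affinity to Substance-K receptor (Rattus norvegicus), read by FRET, tested at 10 uM; on this read-out higher numbers stand for more inhibition at the one concentration tested (going by the name of the read-out) and lower numbers for less inhibition. Compound 2 `C#CCN(Cc1ccccc1)Cc1ccc2ccccc2c1` carries an ethynyl instead and gives 0% in this assay. Compound 3 `O=C(CN(Cc1ccccc1)Cc1ccc2ccccc2c1)N1CCCCC1` carries a (piperidin-1-yl)carbonyl and gives 0% in this assay. The three steps are no change at the digits printed from compound 1 to compound 2 (within the scatter), no change at the digits printed from compound 1 to compound 3 (within the scatter) and no change at the digits printed from compound 2 to compound 3 (within the scatter), so compound 3 stands level with compound 1 and compound 2 and no ordering among them can be read from these numbers.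

Compound 4 `c1ccc(CN(Cc2ccc3ccccc3c2)c2ccccn2)cc1` differs from compound 3 in a different way: pyridin-2-yl in place of ((piperidin-1-yl)carbonyl)methyl on an amine nitrogen. Here the whole chain is removed and the amine nitrogen is joined directly to an aromatic ring. Among the measured compounds shown here, none of the measured steps touched the nitrogen itself; all three changed the group on the saturated chain carbon, and none of them moved the read-out beyond the scatter. For the measured compounds named here, there is thus no measured step that shows a move in either direction, and the step of a number 3 percentage points higher from compound 3 to compound 4 (within the scatter) is expected to stay within the scatter. For compound 4 the estimate in this assay is 3%, with a range from 0% to 15%.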

Compound 4, a percentage reported as inhibition, at one concentration (the size of the read-out at that concentration, not a potency): 17%
Beside the measured number, compound 4's estimate is 14 percentage points below it; measured number above the stated range.
By their numbers in this assay, from the lowest: compounds 1, 2 and 3 (each within the scatter of the next); then compound 4.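

Among the compounds shown here, changing the group on the amine nitrogen itself, rather than only the end of the chain, is the first change to move the number in this assay (this assay) beyond the scatter: pyridin-2-yl gives a number 17 percentage points higher from compound 3 to compound 4 (beyond the scatter), and likewise a number 17 percentage points higher from compound 2 to compound 4 (beyond the scatter) and a number 17 percentage points higher from compound 1 to compound 4 (beyond the scatter). This position therefore responds to the read-out, whereas the cyanomethyl, propargyl and ((piperidin-1-yl)carbonyl)methyl groups all stood level, and a six-membered aromatic ring with one hetero atom is the only group shown here that gives a reading above theirs, though the size of the step is modest and rests on compound 4 alone. Nothing measured here accounts for the step.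

This one change removes the saturated chain and brings in an aromatic ring at the same time, so the compounds shown cannot say which of the two matters, or whether the ring nitrogen plays any part. A phenyl, a pyridin-3-yl or a plain methyl on the same amine nitrogen would help to separate these possibilities.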